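The source may hold more compounds than are shown below. What is called first, only, known or untested is meant among the compounds shown, and "the series" means these compounds.

For the measured compounds named here, in an ADME assay on S9 fraction from liver (Homo sapiens) for metabolic stability, with a stated time of 1 h (on this read-out lower numbers stand for a less stable compound and higher numbers for a more stable compound), compound 1 (`CC(C)(C)Nc1ncc(C(N)=O)c(N[C@@H]2CCC[C@H](O)C2)n1`) gives 93% and compound 2 (`NC(=O)c1cnc(NC2CCCCC2)nc1N[C@@H]1CCC[C@H](O)C1`) gives 77% as the lower of the two numbers so far. Compound 3 (`NC(=O)c1cnc(NC23CC(C2)C3)nc1N[C@@H]1CCC[C@H](O)C1`) keeps everything in compound 2 except the group on a nitrogen on an aromatic ring (a group of 5 heavy atoms (5 carbon; 2 four-membered non-aromatic rings of carbon only) in place of a group of 6 heavy atoms (6 carbon; one six-membered non-aromatic ring of carbon only), on a nitrogen on an aromatic ring). Going by the values given here, one measured step bears on this place, and it is modest but beyond the scatter (a number 16 percentage points lower from compound 1 to compound 2 (beyond the scatter)). In that step cyclohexyl entered in place of tert-butyl and the number fell. Here cyclohexyl leaves, so a modest rise is expected, though one step is thin evidence and the new group has not been tested in this series. The expected step is estimated as a number 11 percentage points higher from compound 2 to compound 3 (beyond the scatter). Compound 3 is therefore estimated at 88% with wide uncertainty (range 72% to 99%).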

Compound 3, percent of the compound remaining: 96%
The estimate for compound 3 lay 8 percentage points below the measured number, and the stated range covers the measured number.
By their numbers in this assay, from the lowest: compound 2; then compounds 1 and 3 (each within the scatter of the next).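

In this assay, for the compounds shown here, the group of 5 carbon atoms in 2 four-membered rings, set in place of cyclohexyl on the nitrogen, gives a number 19 percentage points higher from compound 2 to compound 3 (beyond the scatter), so tert-butyl is no longer the only group here that stands clear of cyclohexyl. Set against tert-butyl, the same group gives a number 3 percentage points higher from compound 1 to compound 3 (within the scatter), so a group with no ring and a group with 2 four-membered rings cannot be told apart at this position on this read-out. Nothing available explains why the cyclohexyl compound stands apart from the other two.

Going by these compounds, it remains open whether cyclobutyl or cyclopentyl on this nitrogen would sit with cyclohexyl or with the other two groups. The compounds shown also leave open how a ring carrying an oxygen atom, such as tetrahydropyranyl, or an open chain such as n-butyl would behave here.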